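The source may hold more compounds than are shown below. What is called first, only, known or untested is meant among the compounds shown, and "the series" means these compounds.

The measured compounds:

compound 1 `O=C(/C=C/c1coc2cc(O)ccc2c1=O)NCc1ccc(F)cc1` — in a functional assay on HeLa cells (Homo sapiens) for inhibition, read by MTT assay, with a stated time of 48 h (on this read-out higher numbers stand for weaker inhibition and lower numbers for stronger inhibition), compound 1 gives > 100000 nM, which is a limit of the assay and not a number.
compound 2 `COc1ccc2c(=O)c(/C=C/C(=O)Nc3ccccc3)coc2c1` — in this assay compound 2 gives > 100000 nM, again a limit rather than a number.
compound 3 `Cc1ccc(CNC(=O)/C=C/c2coc3cc(O)ccc3c2=O)cc1` — in this assay compound 3 gives > 100000 nM, also a limit.

For the measured compounds named here, every value in this set therefore sits at the same place, (the limit of > 100000 nM in this assay, at which 3 of the 3 values shown sit), and no compound can be ranked against another. Going by these compounds, compound 2 stands at that limit with the two others, so where it lies beneath it is unknown. Going by the values given here, the one step between measured compounds, a step that the two limits leave unreadable from compound 1 to compound 3, is unreadable for the same reason, and it concerns the amide substituent on the core of compound 1 rather than the core of compound 2.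

Compound 4 `COc1ccc2c(=O)c(/C=C/C(=O)NCc3ccccc3)coc2c1` differs from compound 2 in one place: benzyl in place of phenyl on an amide-type nitrogen. Cut one bond further out, the change reads anilino to benzylamino. Among the compounds with values here, no measured step tracks this change, and the single step that exists gives no size. With nothing to move the expectation away from the limit, the step from compound 2 to compound 4 in this assay is expected to be about a step that the limit leaves unreadable from compound 2 to compound 4, with no direction that can be read. Compound 4 is accordingly estimated at 120000 nM, within a range from 30000 nM to 500000 nM, and most likely the result will again be only a limit.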

Compound 4, half-maximal inhibitory concentration: 33400 nM
The estimate for compound 4 lay 3.6-fold (0.56 log units) above the measured number; the measured number falls inside the stated range.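

In this assay, the amide-type nitrogen on the core of compound 2 turns out to be a place where a single change can bring a compound down from the limit: benzyl in place of phenyl gives an at least 2.9-fold lower number from compound 2 to compound 4 (0.47 log units; beyond the scatter). The change keeps the six-membered aromatic ring of carbon, brings in no hydrogen-bond donor or acceptor and no net charge, and raises the group only from 6 to 7 heavy atoms, so a difference this small in the substituent is enough to give a step beyond the scatter. Since the value of compound 2 is a limit, the true size of this step stays unknown, and compound 4 is the only compound shown with a measured number, the others remaining at one place: the limit of > 100000 nM in this assay, at which 3 of the 4 values shown sit.

Going by these compounds, the step between compound 1 and compound 3 still cannot be read, so it remains open whether fluoro or methyl on the benzyl ring matters on either core. Also open, on these data alone, is whether a longer chain such as phenethyl, or a basic amine such as dimethylaminoethyl, on the same amide nitrogen would carry the number further down.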